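Fluoro to chloro swap on the pendant phenyl group

The source may hold more compounds than are shown below. What is called first, only, known or untested is meant among the compounds shown, and "the series" means these compounds.

Compound 2 `Nc1scc(-c2ccc(F)cc2)c1C(=O)c1ccccc1` gives 51% in a functional assay on CHO cells for agonist activity at adenosine receptor A1 (Homo sapiens), read by fluorescence and ERK phosphorylation, with stated times of 30 min and 1.5 h, tested at 3 uM (on this read-out lower numbers stand for a weaker effect and higher numbers for a stronger effect at the one concentration tested), and stands level with compound 1 `Nc1scc(-c2cccc(F)c2)c1C(=O)c1ccccc1`, which gives 51% in this assay. Among the measured compounds shown here, the single measured step, no change at the digits printed from compound 1 to compound 2 (within the scatter), shows that 4-fluorophenyl in place of 3-fluorophenyl leaves the read-out where it was. Compound 3 `Nc1scc(-c2cccc(Cl)c2)c1C(=O)c1ccccc1` has not yet been measured; it differs from compound 2 by 3-chlorophenyl in place of 4-fluorophenyl on an aromatic carbon. For the measured compounds named here, the step from compound 1 to compound 2 bears on it in that the substituent returns to the 3-position of the phenyl group, where compound 1 already sits at the same level as compound 2; no measured step covers chlorine in place of fluorine, so that part of the change rests on no datum. Compound 3 is therefore expected to give 51% in this assay, within a range of 36% to 66%. The estimated step of no change at the digits printed from compound 2 to compound 3 (within the scatter) is expected to stay within the scatter.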

Compound 3, a percentage reported as activity, at one concentration (the size of the read-out at that concentration, not a potency): 45%
Compound 3: the middle estimate sits 6 percentage points above what was measured, and the stated range covers the measured number.
By their numbers in this assay, from the lowest: compounds 3, 1 and 2 (each within the scatter of the next).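

In this assay the exchange of halogen alone, chloro in place of fluoro, gives a number 6 percentage points lower from compound 1 to compound 3 (within the scatter) and so adds a second halogen to the series without a read-out outside the scatter. The change of halogen and its place together, 3-chlorophenyl in place of 4-fluorophenyl, gives a number 6 percentage points lower from compound 2 to compound 3 (within the scatter) and likewise stays within the scatter, so all three halogenated phenyl groups at this position read alike at the one concentration tested. No measured data offer an explanation for these read-outs.

On these data alone, the three compounds cover only fluoro and chloro on the phenyl group, so the effect of an amine, a carboxylic acid or a methoxy group there remains open. Also open, as far as these compounds go, is whether 4-chlorophenyl would complete the pattern, and whether these compounds would also read alike at other concentrations.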